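This account rests on a few compounds, and the source may have more. Where it says the series, first, only, none or still open, it means among the compounds named here.

Of the compounds shown here, three have been measured in a functional assay on COLO 205 cells (Homo sapiens) for inhibition, read by sulforhodamine B assay, with a stated time of 48 h, tested at 50 uM; a higher number here means more inhibition of growth at the concentration tested, a lower number less inhibition of growth. Compound 1 `COc1ccc(/C=C/C(=O)/C=C/c2ccc(OCc3cn(CCCCCOc4cc(=O)oc5ccccc45)nn3)c(OC)c2)cc1` gives 30%, the lowest of the three numbers shown. For the measured compounds named here, compound 2 `COc1ccccc1/C=C/C(=O)/C=C/c1ccc(OCc2cn(CCCCOc3cc(=O)oc4ccccc34)nn2)c(OC)c1` gives 47% and compound 3 `COc1cc(/C=C/C(=O)/C=C/c2cccc3ccccc23)ccc1OCc1cn(CCCOc2cc(=O)oc3ccccc23)nn1` gives 64%; both gaps from compound 1 lie beyond the scatter, yet no step between any of these pairs is given, since each pair differs in more than one place.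

Compound 4 `COc1cc(/C=C/C(=O)/C=C/c2ccco2)ccc1OCc1cn(CCCCCOc2cc(=O)oc3ccccc23)nn1` is the next compound to be tested. Against compound 1 the change is furan-2-yl in place of 4-methoxyphenyl on a double-bonded chain carbon bound to a double-bonded chain carbon. Going by the values given here, no measured step of this kind exists, so the direction is open; a modest upward move is expected, though the size is uncertain. For compound 4 an expected step of a number 6 percentage points higher from compound 1 to compound 4 (within the scatter) leads to an estimate of 36%, with a range from 16% to 56%.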

Compound 4, percent growth inhibition at one concentration: 33%
Compound 4: middle estimate off by 3 percentage points, on the high side; the measured number falls inside the stated range.
By their numbers in this assay, from the lowest: compounds 1 and 4 (each within the scatter of the next); then compound 2; then compound 3.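

In this assay, for the compounds shown here, furan-2-yl in place of 4-methoxyphenyl gives the first single-place step: a number 3 percentage points higher from compound 1 to compound 4 (within the scatter). At this place, on a double-bonded chain carbon bound to a double-bonded chain carbon, the two aromatic groups are therefore not separated by this read-out, despite the change from a six-membered to a five-membered ring. Nothing at hand bears on a cause for this result.

From the compounds shown here alone, whether an amine or a carboxylic acid at this place would give a step beyond the scatter remains open. Steps to compound 2 and compound 3 cannot be read, so no single change can be credited for their printed numbers.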